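Amide to Urea Step on a Pyrazole Series

The compounds below may be only part of what the source reports. "The series", "measured", "known", "first", "only" and "open" are said of these compounds alone.

Measured compounds:
compound 1 `COc1cc(-c2nn(-c3cccc(NC(=O)Nc4cc(C(F)(F)F)cc(C(F)(F)F)c4)c3)cc2-c2ccncc2)ccc1Cl` gives 1150 nM;
compound 2 `COc1cc(-c2nn(-c3cccc(NC(=O)c4cccc(C(F)(F)F)c4)c3)cc2-c2ccncc2)ccc1Cl` gives 3120 nM;
compound 3 `O=C(Nc1cccc(-n2cc(-c3ccncc3)c(-c3ccc(Cl)c(O)c3)n2)c1)Nc1ccc(Cl)c(Cl)c1` gives 1910 nM.

In a functional assay on HOP-92 cells (Homo sapiens) for inhibition, read by sulforhodamine B assay, with a stated time of 48 h (a lower number here means a stronger inhibitor of growth, a higher number a weaker inhibitor of growth), compound 2 stands at the highest of the three numbers. Compound 3 lies close to it, and the gap between these two falls within the scatter of the measurement. Compound 1 lies further off, and that gap goes beyond the scatter, so compound 2 is the weaker of that pair.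

Compound 4 `COc1cc(-c2nn(-c3cccc(NC(=O)Nc4cccc(C(F)(F)F)c4)c3)cc2-c2ccncc2)ccc1Cl` has not yet been measured. It differs from compound 2 in one place: (3-(trifluoromethyl)phenyl)amino in place of 3-(trifluoromethyl)phenyl on a carbonyl carbon. Compound 1 and compound 3 both carry an amino group on that carbonyl carbon, as compound 4 does, and both sit at lower numbers than compound 2, one of them beyond the scatter. On that basis a modest move toward a lower number is expected from compound 2 to compound 4, with a real chance that the step stays within the scatter; the expected step is a 2.1-fold lower number from compound 2 to compound 4 (0.32 log units; beyond the scatter). Compound 4 is estimated at 1500 nM, within a range from 600 nM to 4000 nM.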

Compound 4, concentration for total growth inhibition: 1770 nM
Compound 4: the middle estimate sits 1.2-fold (0.07 log units) below what was measured; low and high end bracket the measured number.
By their numbers in this assay, from the lowest: compounds 1, 4, 3 and 2 (each within the scatter of the next, the first and the last beyond it).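

In this assay, (3-(trifluoromethyl)phenyl)amino in place of 3-(trifluoromethyl)phenyl on a carbonyl carbon gives a 1.8-fold lower number from compound 2 to compound 4 (0.25 log units; within the scatter), so this direct comparison does not separate the amide from the urea at this place. Hydrogen in place of trifluoromethyl on an aromatic carbon gives a 1.5-fold higher number from compound 1 to compound 4 (0.19 log units; within the scatter), so that trifluoromethyl is not separated from hydrogen either. Neither single change, taken alone, goes beyond the scatter. Nothing in the data shown bears on why these steps have the sizes they do. On these data alone, it remains open whether a smaller group on that carbonyl carbon, such as methylamino or methoxy, would give a step beyond the scatter. As far as these compounds go, it also remains open whether a nitrile or a carboxylic acid on that aromatic carbon would separate from hydrogen there.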